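The compounds below may be only part of what the source reports. "The series", "measured", "known", "first", "only" and "open" are said of these compounds alone.

Three compounds are on record, and for none of them has this assay returned a number. Compound 1 `Cc1cccc(CSc2ccc3c(C)cc(=O)oc3c2)c1` gives > 33700 nM in a functional assay on KB cells (Homo sapiens) for antiproliferative activity, read by sulforhodamine B assay, with a stated time of 72 h (a lower number here means a stronger inhibitor of growth, a higher number a weaker inhibitor of growth), which is a limit of the assay rather than a measured value. Compound 2 `CCc1cc(=O)c2ccc(Sc3cccc(Cl)[n+]3[O-])c(C)c2o1` gives > 28700 nM in this assay, again a limit. Compound 3 `CCc1cc(=O)c2ccc(OCc3ccccc3)c(C)c2o1` gives > 33900 nM in this assay, also a limit, so where compound 3 stands can only be stated as the limit of > 33900 nM in this assay, at which 1 of the 3 values shown sits, with the other two compounds sitting at the limit of > 28700 nM in this assay, at which 1 of the 3 values shown sits, and (the limit of > 33700 nM in this assay, at which 1 of the 3 values shown sits). For the measured compounds named here, no step between measured compounds can be drawn from three limits.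

Compound 4 `CCc1cc(=O)c2ccc(OCc3cccc(C(F)(F)F)c3)c(C)c2o1` differs from compound 3 by trifluoromethyl in place of hydrogen on an aromatic carbon. With nothing but limits to go on, no step beyond the scatter is expected in either direction; the step that the limit leaves unreadable from compound 3 to compound 4 is estimated to stay within the usual scatter. Compound 4 is therefore expected to give about 35000 nM, somewhere between 8000 nM and 150000 nM, and most likely the assay will once more report only a limit.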

Compound 4, concentration for 50% growth inhibition: > 27600 nM
Compound 4: only a limit was reported; the forecaster's own chance of this, stated with the estimate: 70%; the middle value is on the limit's open side.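

Compound 3 and compound 4 both carry only a limit in this assay, so no step can be read for trifluoromethyl in place of hydrogen on an aromatic carbon. The compounds shown leave open what concentration, if any, would give a measured number in this assay.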